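The source may report more compounds than this note shows. Statements on the series, on what has been measured and on what is new or still open speak of the compounds shown alone.

For the measured compounds named here, compound 1 `c1ccc([C@H]2CCC[C@@H](CCN3CCN(c4ccccc4)CC3)C2)cc1` is one of only two compounds measured in an assay on membranes from liver for displacement of a labelled ligand from Sigma intracellular receptor 2 (Rattus norvegicus), read by scintillation counting, with a stated time of 120 min (a higher number here means a weaker inhibitor, a lower number a stronger inhibitor), and in this assay compound 1 gives 118 nM. Compound 2 `c1ccc(CNCC[C@@H]2CCC[C@H](c3ccccc3)C2)cc1`, built differently, gives 130 nM; 49 nM (2 entries), recorded as the several entries of compound 2 in this assay, 130 nM; 49 nM (2 entries), so compound 1 has no measured partner that differs from it in one place alone. Compound 3 `c1ccc([C@H]2CCC[C@H](CCN3CCN(c4ccccc4)CC3)C2)cc1` keeps every atom and bond of compound 1; the difference is the two compounds have the same atoms and bonds and differ only in configuration as drawn: 1 of 2 stereo elements differ; a stereocentre at a saturated ring carbon is drawn R in compound 1 and S in compound 3. Going by the values given here, no measured pair shows such a change of configuration, so its direction is open, and one expects a step from compound 1 to compound 3 of a 1.7-fold higher number from compound 1 to compound 3 (0.23 log units; within the scatter), scarcely beyond the scatter. Compound 3 is thus estimated at 200 nM, in the range 60 nM to 700 nM.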

Compound 3, inhibition constant: 144 nM
Beside the measured number, compound 3's estimate is 1.4-fold (0.14 log units) above it; the measured number falls inside the stated range.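

In this assay, the change from R to S at this saturated ring carbon now has a measured size: a 1.2-fold higher number from compound 1 to compound 3 (0.09 log units; within the scatter). This gives the change of configuration its first reading, and the pair cannot be told apart at this carbon. The entries for one compound can themselves lie well apart: the several entries of compound 2 in this assay, 130 nM; 49 nM (2 entries)

The compounds shown leave open what a change at the other stereo element would do. They also leave open whether this configuration would count for more if the core of compound 1 carried a longer chain or a carboxylic acid.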